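The source may hold more compounds than are shown below. What is called first, only, known or untested is meant among the compounds shown, and "the series" means these compounds.

Compound 1, with the structure `CCCc1nc(-c2ccccc2)c(CNCCN2CCN(c3ccccc3Cl)CC2)o1`, is measured in an assay on HEK293 cells for inhibition of Voltage-dependent T-type calcium channel subunit alpha-1G (Homo sapiens), read by fluorescence, tested at 10 uM (a higher number here means more inhibition at the concentration tested (going by the name of the read-out), a lower number less inhibition), where compound 1 gives 60.1%. Two related compounds share its core. Compound 2, with the structure `CCCc1nc(-c2ccccc2)c(CNCCCN2CCN(c3cccc(C)c3C)CC2)o1`, gives 55.2% in this assay, and compound 3, with the structure `CCCc1nc(-c2ccccc2)c(CNCCCN2CCN(c3cccc(C)c3)CC2)o1`, gives 47.8%. Within the data shown here, the one step between measured compounds that differ in a single place is a number 7.4 percentage points lower from compound 2 to compound 3 (within the scatter). Compound 1 holds the highest of the three numbers; compound 2 lies within the scatter of it, and only compound 3 lies beyond the scatter.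

The compound of interest is compound 4, with the structure `CCCc1nc(-c2ccccc2)c(CNCCN2CCN(c3ccc(Cl)cc3)CC2)o1`. It differs from compound 1 in one place: 4-chlorophenyl in place of 2-chlorophenyl on an amine nitrogen in a ring. Among the measured compounds shown here, no measured step moves a chlorine around its ring; the single measured step concerns a methyl removed from an aromatic carbon and stays within the scatter. For the measured compounds named here, there is thus nothing among the measured compounds that points to a step beyond the scatter in either direction for this change, and the expectation for compound 4 is accordingly a step close to zero, a number 4.1 percentage points lower from compound 1 to compound 4 (within the scatter). Compound 4 is estimated to give 56% in this assay, with a range from 36% to 76%.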

Compound 4, a percentage reported as inhibition, at one concentration (the size of the read-out at that concentration, not a potency): 55.8%
The estimate for compound 4 lay 0.2 percentage points above the measured number, within the range that was stated.
By their numbers in this assay, from the lowest: compounds 3, 2, 4 and 1 (each within the scatter of the next, the first and the last beyond it).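

Exchanging 2-chlorophenyl for 4-chlorophenyl on the amine nitrogen in the ring gives a number 4.3 percentage points lower from compound 1 to compound 4 (within the scatter) in this assay. This is the first step shown that leaves the atoms unchanged and alters only where the chlorine sits on the phenyl ring, and at this single test concentration the two placements cannot be told apart. Together with the earlier a number 7.4 percentage points lower from compound 2 to compound 3 (within the scatter), it makes a second change on this aromatic group that stays within the usual variation between repeats, though the two steps concern different substituents on different chains, and nothing measured here explains why the two chlorophenyl compounds read so alike.

The compounds shown leave open whether a phenyl ring with no chlorine, or one carrying a methoxy group, a fluorine or a nitrile in its place, would read differently on the chain of compound 1. They also leave open whether moving the chlorine would have a similarly small effect on the longer chain of compound 2 and compound 3, and a read-out at one concentration does not settle how the potencies of compound 1 and compound 4 compare.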